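Ethyl in Place of Hydrogen on a Carboxylic Acid

The compounds below may be only part of what the source reports. "The series", "measured", "known", "first", "only" and "open" are said of these compounds alone.

Measured compounds:
compound 1 `COc1ccc(OC(=O)c2nc(C)c(C)nc2C)c(/C=C/C(=O)O)c1`, 45%
compound 2 `COc1ccc(/C=C/C(=O)O)cc1OC(=O)c1nc(C)c(C)nc1C`, 128%
compound 3 `CCOC(=O)/C=C/c1ccc(OC)c(OC(=O)c2nc(C)c(C)nc2C)c1`, 60.1%

Of the compounds shown here, three have been tested in a functional assay on EA.hy 926 cells (Homo sapiens) for cytotoxicity, read by MTT assay, with stated times of 24 h and 12 h, tested at 25 uM; a lower number here means a weaker effect, a higher number a stronger effect of the compound at the concentration tested. Compound 2 gives 128%, and compound 3 gives 60.1%; the change between them, (ethyl in place of hydrogen on an oxygen next to a carbonyl group), made a step of a number 67.9 percentage points lower from compound 2 to compound 3 (beyond the scatter). Compound 1 gives 45%, the lowest of the three numbers; compound 1 and compound 2 share the same atoms joined differently, and the difference between the two cores is not broken down here.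

Compound 4 `CCOC(=O)/C=C/c1cc(OC)ccc1OC(=O)c1nc(C)c(C)nc1C` has not yet been measured. It arises from compound 1 by ethyl in place of hydrogen on an oxygen next to a carbonyl group, the same change as that from compound 2 to compound 3, at the same place. Compound 1, however, already stands low, so the expected step of a number 20 percentage points lower from compound 1 to compound 4 (beyond the scatter) in this assay is smaller than the earlier one; this rests on compound 1 giving 45% and on the step of a number 67.9 percentage points lower from compound 2 to compound 3 (beyond the scatter). Compound 4 is therefore estimated at 25%, expected between 5% and 50%.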

Compound 4, a percentage reported as activity, at one concentration (the size of the read-out at that concentration, not a potency): 23.4%
Compound 4: the middle estimate sits 1.6 percentage points above what was measured, within the range that was stated.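

In this assay, ethyl in place of hydrogen on an oxygen next to a carbonyl group gave a number 21.6 percentage points lower from compound 1 to compound 4 (beyond the scatter), so the number fell on both cores. For the compounds shown here, the direction of the step therefore carried over from one core to the other, but its size did not: the same change on two cores in this assay, a number 67.9 percentage points lower (beyond the scatter) from compound 2 to compound 3 and a number 21.6 percentage points lower (beyond the scatter) from compound 1 to compound 4, 46.3 percentage points apart, beyond the scatter of two such steps With only two pairs, this shows that the size of the step depends on the core in these compounds, but it does not explain why the two steps differ, and it gives no rule for predicting the step on a further core.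

The compounds shown leave open what a longer chain on that oxygen, such as propyl or butyl, or an amide in place of the ethyl ester, would do on either core. They also leave open whether the same difference between the two cores would appear at other concentrations or in any read-out other than this assay.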